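Replacing the Acetoxy Side Chain with a Triazole

The source may report more compounds than this note shows. Statements on the series, on what has been measured and on what is new or still open speak of the compounds shown alone.

Compound 1 `CN1CCN(C[C@H]2CN(c3ccc(-n4cc(-c5ccccn5)cn4)c(F)c3)C(=O)O2)CC1` gives 70 ug/mL in an ADME assay on L02 cells (Homo sapiens) for cytotoxicity, read by MTT assay, with a stated time of 48 h; a lower number here means a stronger inhibitor, a higher number a weaker inhibitor.
Compound 2 `O=C1CNC(=O)N1C[C@H]1CN(c2ccc(-n3cc(-c4ccccn4)cn3)c(F)c2)C(=O)O1` gives > 400 ug/mL in this assay.
Compound 3 `CC(=O)OC[C@H]1CN(c2ccc(-n3cc(-c4ccccn4)cn3)c(F)c2)C(=O)O1` gives > 400 ug/mL in this assay.

Compound 3 stands at a limit of this assay, not at a number. Compound 2 also stands at that limit, as the limit of > 400 ug/mL in this assay, at which 2 of the 3 values shown sit, records. Only compound 1 gives a readable number. Compound 4 `O=C1O[C@@H](Cn2ccnn2)CN1c1ccc(-n2cc(-c3ccccn3)cn2)c(F)c1` differs from compound 3 by 1H-1,2,3-triazol-1-yl in place of acetoxy on a saturated chain carbon bound to a saturated ring carbon. Within the data shown here, no measured step bears directly on this change: an at least 5.7-fold higher number from compound 1 to compound 2 (0.75 log units; beyond the scatter) and an at least 5.7-fold higher number from compound 1 to compound 3 (0.75 log units; beyond the scatter) both start from the methylpiperazinyl of compound 1, and a step that the two limits leave unreadable from compound 2 to compound 3. Both side groups seen so far in place of the methylpiperazinyl leave the number beyond the limit, so little change is expected here. The step of a number no higher from compound 3 to compound 4 (the limit leaves the size open) is expected to be small. Compound 4 is estimated at 400 ug/mL, between 150 ug/mL and 1000 ug/mL.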

Compound 4, half-maximal inhibitory concentration: 49 ug/mL
Beside the measured number, compound 4's estimate is 8.2-fold (0.91 log units) above it, outside the stated range (below it).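

In this assay, among these compounds, 4-methylpiperazin-1-yl is not the only side group on this saturated chain carbon that gives a readable number, as 1H-1,2,3-triazol-1-yl shows an at least 8.1-fold lower number from compound 3 to compound 4 (0.91 log units; beyond the scatter) and an at least 8.1-fold lower number from compound 2 to compound 4 (0.91 log units; beyond the scatter). From the compounds shown here alone, those two steps start from a limit, so their full size stays open: the limit of > 400 ug/mL in this assay, at which 2 of the 4 values shown sit. The two groups give matching results, with a 1.4-fold lower number from compound 1 to compound 4 (0.15 log units; within the scatter).

Going by these compounds, what remains open is whether the aromatic ring or its nitrogens drive this. An imidazole or a simple open-chain amine at this carbon would help test that.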